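The source may hold more compounds than are shown below. What is called first, only, known or untested is meant among the compounds shown, and "the series" means these compounds.

Measured so far: compound 1 `C=C(C)[C@@H]1CC=C(Cn2cc(COc3ccc(C4NC(=O)NC(C)=C4C(=O)OCC)cc3)nn2)CC1` gives 12400 nM; compound 2 `C=C(C)[C@@H]1CC=C(Cn2cc(COc3ccc(C4NC(=O)NC(C)=C4C(=O)OCC)cc3OC)nn2)CC1` gives 11300 nM; compound 3 `C=C(C)[C@@H]1CC=C(Cn2cc(COc3cccc(C4NC(=O)NC(C)=C4C(C)=O)c3)nn2)CC1` gives 30500 nM.

All three were tested in a functional assay on U-251 cells (Homo sapiens) for inhibition, read by sulforhodamine B assay, with a stated time of 48 h; on this read-out higher numbers stand for weaker inhibition of growth and lower numbers for stronger inhibition of growth. Compound 1 and compound 2 differ by methoxy in place of hydrogen on an aromatic carbon, and in this assay the step is a 1.1-fold lower number from compound 1 to compound 2 (0.04 log units; within the scatter). Compound 3 carries a different core; the difference between the two cores is not broken down here. Its number is the highest of the three, beyond the scatter from compound 1 and from compound 2.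

Compound 4 `C=C(C)[C@@H]1CC=C(Cn2cc(COc3cc(C4NC(=O)NC(C)=C4C(C)=O)ccc3OC)nn2)CC1` is not yet measured. It differs from compound 3 by methoxy in place of hydrogen on an aromatic carbon. This is the same kind of change as from compound 1 to compound 2, though the place differs: in compound 2 the methoxy is meta to a large group, in compound 4 it is para to a large group. Since the earlier change gave a 1.1-fold lower number from compound 1 to compound 2 (0.04 log units; within the scatter), a step of about a 1.1-fold lower number from compound 3 to compound 4 (0.04 log units; within the scatter) is expected here. Compound 4 is therefore estimated at 28000 nM, roughly between 12000 nM and 65000 nM, resting on the value of compound 3 and on the small earlier step.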

Compound 4, concentration for total growth inhibition: > 100000 nM
Compound 4 was reported as a limit; the forecaster's own chance of this, stated with the estimate: 10%; at least 3.5-fold (0.55 log units) between middle value and limit.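

In this assay compound 4 gives > 100000 nM, which is a limit of the assay and not a number. Methoxy in place of hydrogen on an aromatic carbon gives an at least 3.2-fold higher number from compound 3 to compound 4 (0.51 log units; beyond the scatter), so the change does not carry over unaltered from the core of compound 1 to the core of compound 3: the same change on two cores in this assay, a 1.1-fold lower number (0.04 log units; within the scatter) from compound 1 to compound 2 and an at least 3.2-fold higher number (0.51 log units; beyond the scatter) from compound 3 to compound 4, at least 3.5-fold (0.55 log units) apart, beyond the scatter of two such steps The two pairs differ in the place of the methoxy as well as in the core, so these compounds cannot separate the two, and the full size of the new step remains unknown: the limit of > 100000 nM in this assay, at which 1 of the 4 values shown sits.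

The compounds shown leave open how a methoxy would behave at the same place on both cores. They also leave open whether a different group at that place, such as an amine or a carboxylic acid, would give a similar result on each core.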